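The source may report more compounds than this note shows. Statements on the series, on what has been measured and on what is new or still open speak of the compounds shown alone.

Among the compounds with values here, compound 2 `Cc1cccc(NC(=O)c2cc3cc(C)ccc3oc2=O)c1` gives 10000 nM in an assay on isolated protein for inhibition of coagulation factor XII (Homo sapiens) (a higher number here means a weaker inhibitor, a lower number a stronger inhibitor), the lowest of the two numbers measured so far, while compound 1 `Cc1ccc2oc(=O)c(C(=O)Nc3ccccc3)cc2c1` gives 23000 nM. The step of a 2.3-fold lower number from compound 1 to compound 2 (0.36 log units; beyond the scatter) shows that adding a methyl to the aromatic ring on the amide nitrogen brought a modest gain. Compound 3 `Cc1ccc2oc(=O)c(C(=O)Nc3ccc(Cl)cc3)cc2c1` alters that same ring in a different way: 4-chlorophenyl in place of 3-methylphenyl on an amide-type nitrogen. Within the data shown here, no measured step covers a chlorine here; the only step at hand, a 2.3-fold lower number from compound 1 to compound 2 (0.36 log units; beyond the scatter), shows that a single small substituent on this ring shifted the number by a modest amount. The swap of one small substituent for another is therefore expected to leave the number close to that of compound 2, with a step of a 1.2-fold higher number from compound 2 to compound 3 (0.08 log units; within the scatter) that may stay within the scatter. Compound 3 is estimated to give 12000 nM in this assay, with a likely range from 5000 nM to 30000 nM.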

Compound 3, half-maximal inhibitory concentration: 34000 nM
Compound 3: the middle estimate sits 2.8-fold (0.45 log units) below what was measured, and the stated range ends below it.
By their numbers in this assay, from the lowest: compound 2; then compounds 1 and 3 (each within the scatter of the next).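

In this assay, the ring on the amide-type nitrogen proves sensitive to which substituent it carries: the swap of 3-methylphenyl for 4-chlorophenyl gives a 3.4-fold higher number from compound 2 to compound 3 (0.53 log units; beyond the scatter) and so is not a neutral exchange of one small group for another. Set against the plain phenyl, the chloro compound shows a 1.5-fold higher number from compound 1 to compound 3 (0.17 log units; within the scatter) and thus no measurable gain, so among these compounds the modest improvement belongs to the 3-methylphenyl group alone, and a substituent on this ring does not bring one by itself. Nothing measured here accounts for this difference.

Going by these compounds, compound 2 and compound 3 differ in both the kind of substituent and its place on the ring, so which of the two matters remains open. On these data alone, how an amine or a carboxylic acid on this ring would behave also remains open.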